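The source may report more compounds than this note shows. Statements on the series, on what has been measured and on what is new or still open speak of the compounds shown alone.

Working notes on the series. Compound 1 `O=C(Nc1ccc(Br)cc1)c1csc(Cc2c(Cl)cccc2Cl)n1` gives 460 nM in an assay on CHO cells, read by calcium flux; on this read-out lower numbers stand for stronger inhibition and higher numbers for weaker inhibition. Compound 2 `N#Cc1ccc(NC(=O)c2csc(Cc3c(Cl)cccc3Cl)n2)cc1` gives 720 nM in this assay, and the step of a 1.6-fold higher number from compound 1 to compound 2 (0.19 log units; within the scatter) stays within the scatter. Compound 3 `COc1ccc(NC(=O)c2csc(Cc3c(Cl)cccc3Cl)n2)cn1` reaches only a limit of the assay, > 4000 nM, so no number is known for it. Against the two measured compounds the steps of an at least 8.6-fold higher number from compound 1 to compound 3 (0.93 log units; beyond the scatter) and an at least 5.5-fold higher number from compound 2 to compound 3 (0.74 log units; beyond the scatter) are both beyond the scatter, so compound 3 stands at the weak end of what has been measured, at the limit (the limit of > 4000 nM in this assay, at which 1 of the 3 values shown sits).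

Compound 4 `O=C(Nc1ccc(Br)cn1)c1csc(Cc2c(Cl)cccc2Cl)n1` follows from compound 3 by 5-bromopyridin-2-yl in place of 6-methoxypyridin-3-yl on an amide-type nitrogen. The change reverses the sort of exchange seen in the step from compound 1 to compound 3, bringing back a bromo substituent, though on a pyridine rather than a phenyl ring, and the pyridine nitrogen now sits on the ring carbon joined to the amide nitrogen. The expectation is a move back toward the level of compound 1 460 nM, in the direction of lower numbers, of a size comparable to the step from compound 1 to compound 3, though a weaker number than compound 1 remains plausible. Compound 4 is therefore estimated at 1000 nM, within 300 nM to 4000 nM, which corresponds to an expected step of an at least 4.0-fold lower number from compound 3 to compound 4 (0.60 log units; beyond the scatter).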

Compound 4, half-maximal inhibitory concentration: > 4000 nM
Compound 4 was reported as a limit (the forecaster's own chance of this, stated with the estimate: 20%); at least 4.0-fold (0.60 log units) between middle value and limit.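

In this assay, 5-bromopyridin-2-yl in place of 4-bromophenyl on the amide-type nitrogen gives an at least 8.6-fold higher number from compound 1 to compound 4 (0.93 log units; beyond the scatter), so retaining a bromo substituent does not retain a measurable value once this pyridine ring replaces the phenyl ring. The comparison with the nitrile-bearing phenyl compound runs the same way, with an at least 5.5-fold higher number from compound 2 to compound 4 (0.74 log units; beyond the scatter). The step between the two pyridine compounds cannot be read, since each is reported only as a limit: the limit of > 4000 nM in this assay, at which 2 of the 4 values shown sit.

Still open, as far as these compounds go, is whether every pyridine on the amide-type nitrogen stays at this limit, or whether one carrying an amine or a chlorine in place of the bromo substituent returns to a measurable number. Also open, from the compounds shown here alone, is how a phenyl ring carrying a carboxylic acid would read in this assay.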